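Thiophen-3-yl to iodo on a series at its limit

The compounds below may be only part of what the source reports. "The series", "measured", "known", "first", "only" and "open" are said of these compounds alone.

Values in a functional assay on HL-60 cells (Homo sapiens) for antiproliferative activity, read by XTT assay, with a stated time of 72 h (a lower number here means a stronger inhibitor, a higher number a weaker inhibitor), all of them limits rather than numbers:
- Compound 1 (`Nc1nc(N)c2c(-c3ccsc3)cn([C@@H]3O[C@H](CO)[C@@H](O)[C@H]3O)c2n1`) > 20000 nM
- Compound 2 (`Cc1nc(N)c2c(-c3ccsc3)cn([C@@H]3O[C@H](CO)[C@@H](O)[C@H]3O)c2n1`) > 20000 nM
- Compound 3 (`COc1nc(N)nc2c1c(-c1ccccc1)cn2[C@@H]1O[C@H](CO)[C@@H](O)[C@H]1O`) > 20000 nM

Compound 2 offers only a limit, not a number, and the whole series stands at the limit of > 20000 nM in this assay, at which 3 of the 3 values shown sit. Compound 4 (`Cc1nc(N)c2c(I)cn([C@@H]3O[C@H](CO)[C@@H](O)[C@H]3O)c2n1`) differs from compound 2 as follows: iodo in place of thiophen-3-yl on an aromatic carbon. Among the compounds with values here, the only measured step, a step that the two limits leave unreadable from compound 1 to compound 2, lies at another place and gives no size. Within the data shown here, no measured compound carries iodo, so the data give no size for this change. In this assay the expectation is a small shift at most, towards stronger inhibition if any. The estimated step is an at least 1.3-fold lower number from compound 2 to compound 4 (0.12 log units; that floor lies within the scatter). For compound 4 the estimate is 15000 nM, with an expected range from 2000 nM to 20000 nM.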

Compound 4, half-maximal inhibitory concentration: 2050 nM
Compound 4: the middle estimate sits 7.3-fold (0.86 log units) above what was measured; measured number inside the range.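

In this assay the aromatic carbon two ring bonds from the ring nitrogen proves responsive: iodo in place of thiophen-3-yl gives an at least 9.7-fold lower number from compound 2 to compound 4 (0.98 log units; beyond the scatter) and so moves the series off its limit. As far as these compounds go, compound 2 holds only a limit, so this step is a floor and its full size remains unknown. Compound 4 is the only compound shown with a number rather than a limit, against the rest of the series: the limit of > 20000 nM in this assay, at which 3 of the 4 values shown sit.

From the compounds shown here alone, whether bromo or ethynyl at this carbon would also give a number remains open. Going by these compounds, with the step between the amino and methyl compounds unreadable, the effect of amino in place of methyl alongside iodo is also open.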